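Heptyl replaces the ring on a carbonyl carbon

The source may hold more compounds than are shown below. What is called first, only, known or untested is meant among the compounds shown, and "the series" means these compounds.

Going by the values given here, in an ADME assay on a cell-free system (plasma, Sus scrofa) for metabolic stability, read by LC-MS, with a stated time of 1 h, tested at 10 uM (a lower number here means that less of the compound is left, a higher number that more of the compound is left), compound 1 `CC(=O)NCCCC[C@H](NC(=O)[C@@H]1Cc2ccccc2CN1)C(=O)N[C@@H](CCC(=O)C=[N+]=[N-])C(=O)OC(C)C` gives 62%, the lower of only two numbers so far. Compound 2 `CC(=O)NCCCC[C@H](NC(=O)[C@@H]1Cc2ccccc2CN1C(C)=O)C(=O)N[C@@H](CCC(=O)C=[N+]=[N-])C(=O)OC(C)C` gives 98%. Among the compounds with values here, the single measured step, a number 36 percentage points higher from compound 1 to compound 2 (beyond the scatter), is large and beyond the scatter; it places acetyl in place of hydrogen on an amine nitrogen in a ring. Compound 3 `CCCCCCCC(=O)N[C@@H](CCCCNC(C)=O)C(=O)N[C@@H](CCC(=O)C=[N+]=[N-])C(=O)OC(C)C` has not yet been measured. Its change is a different one: heptyl in place of 1,2,3,4-tetrahydroisoquinolin-3-yl on a carbonyl carbon. With heptyl in place of 1,2,3,4-tetrahydroisoquinolin-3-yl on a carbonyl carbon, the hydrogen-bearing ring nitrogen of compound 1 is gone, as it is in compound 2 in another way. Within the data shown here, no measured step tests heptyl itself, so this comparison is only a loose guide. The expected change is upward, probably somewhat smaller than the measured one: a number 23 percentage points higher from compound 1 to compound 3 (beyond the scatter). Compound 3 is estimated at 85%, with an expected range of 65% to 100%.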

Compound 3, percent of the compound remaining: 91%
Compound 3: middle estimate off by 6 percentage points, on the low side; the measured number falls inside the stated range.
By their numbers in this assay, from the lowest: compound 1; then compounds 3 and 2 (each within the scatter of the next).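

In this assay, heptyl in place of 1,2,3,4-tetrahydroisoquinolin-3-yl on a carbonyl carbon gives a number 29 percentage points higher from compound 1 to compound 3 (beyond the scatter) and so shows that a high number at this position does not depend on keeping the ring. The earlier step kept the ring and changed only its nitrogen, whereas this one removes the ring entirely and puts an open chain there. In both steps the ring amine hydrogen of compound 1 is gone and the number rises, but nothing measured here explains why.

As far as these compounds go, it remains open whether a chain carrying a free amine, such as aminoheptyl, would bring the number back down. Also unresolved is whether a shorter chain such as propyl, or a plain phenyl ring, would hold it as heptyl does.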